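The source may report more compounds than this note shows. Statements on the series, on what has been measured and on what is new or still open speak of the compounds shown alone.

Compound 1 `CCOC(=O)c1c(C)oc2ncnc(Nc3cccc(Br)c3)c12`: > 1000000 nM (a limit)
Compound 2 `CCOC(=O)c1c(C)oc2ncnc(Nc3ccccc3)c12`: 851000 nM

Both compounds were tested in a functional assay on MCF7 cells (Homo sapiens) for cytotoxicity, read by MTT assay, with a stated time of 72 h; a lower number here means a stronger inhibitor, a higher number a weaker inhibitor. Compound 1 gives > 1000000 nM, which is a limit and not a number. Compound 1 sits at the limit of > 1000000 nM in this assay, at which 1 of the 2 values shown sits. Among the compounds with values here, compound 2 gives 851000 nM, the only actual number so far, so there is no wider series against which to rank it.

Compound 3 `CCOC(=O)c1c(C)oc2ncnc(Nc3cccc(OC)c3)c12` is compound 2 with one change: methoxy in place of hydrogen on an aromatic carbon. In words, it has methoxy in place of hydrogen on an aromatic carbon, meta to a large group.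

Within the data shown here, only one measured step bears on this change: an at least 1.1-fold lower number from compound 1 to compound 2 (0.07 log units; that floor lies within the scatter). That step involves a different group, and it offers no sign of a large effect from a change on this ring. From the compounds shown here alone, no step beyond the scatter is therefore expected in this assay, and the direction remains open. The expected change is a 1.1-fold lower number from compound 2 to compound 3 (0.03 log units; within the scatter). Compound 3 could also be reported only as a limit. For compound 3, the estimated value is 800000 nM, with an expected range of 300000 nM to 1500000 nM.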

Compound 3, half-maximal inhibitory concentration: > 1000000 nM
Compound 3 ended at the assay's limit; the forecaster's own chance of this, stated with the estimate: 35%; at least 1.2-fold (0.09 log units) between middle value and limit.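

In this assay compound 3 gives > 1000000 nM, which is a limit and not a number. Replacing hydrogen with methoxy gives an at least 1.1-fold higher number from compound 2 to compound 3 (0.07 log units; that floor lies within the scatter), so this change, like the earlier change from bromo to hydrogen at the same place on the ring, is not shown to shift the result beyond ordinary scatter. Bromo and methoxy, two different groups meta to a large group, now end at the same limit, so the step between compound 1 and compound 3 cannot be read, and the measurements cannot rank these two groups: the limit of > 1000000 nM in this assay, at which 2 of the 3 values shown sit.

From the compounds shown here alone, how far compound 1 and compound 3 lie past that limit remains unknown, so a real difference from compound 2 could be hidden, or there could be almost none. Going by these compounds, it also remains open whether an amine, a carboxylic acid or a longer chain such as ethoxy at this place would bring the number clearly down, or whether all changes here stay close to the limit.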